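Urea aryl swap on the shared core: chloro for dimethoxy

The source may report more compounds than this note shows. Statements on the series, on what has been measured and on what is new or still open speak of the compounds shown alone.

Compound 1 `CC(=O)Nc1nn(-c2ccccc2)c(=O)c2ccccc12` gives 52% in an assay on CHO cells for displacement of a labelled ligand from adenosine receptor A1 (Homo sapiens), tested at 10 uM; on this read-out higher numbers stand for more inhibition at the one concentration tested (going by the name of the read-out) and lower numbers for less inhibition. Compound 2 `COc1ccc(OC)c(NC(=O)Nc2nn(-c3ccccc3)c(=O)c3ccccc23)c1` gives 0% in this assay, the lowest of the two numbers, a gap to compound 1 that lies beyond the scatter. Compound 3 `O=C(Nc1ccc(Cl)cc1)Nc1nn(-c2ccccc2)c(=O)c2ccccc12` carries the change (4-chlorophenyl in place of 2,5-dimethoxyphenyl on an amide-type nitrogen). Within the data shown here, no measured step of this kind exists, so any expectation for compound 3 rests on the low reading of compound 2 alone. The expected step of a number 15 percentage points higher from compound 2 to compound 3 (beyond the scatter) is small, upward, and at most just beyond the scatter. For compound 3 an inhibition of 15% is estimated, with a range from 0% to 45%.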

Compound 3, a percentage reported as inhibition, at one concentration (the size of the read-out at that concentration, not a potency): 10%
Beside the measured number, compound 3's estimate is 5 percentage points above it; the range from low to high includes it.
By their numbers in this assay, from the lowest: compounds 2 and 3 (each within the scatter of the next); then compound 1.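

In this assay the aryl swap on the amide-type nitrogen reads as a number 10 percentage points higher from compound 2 to compound 3 (within the scatter), so the low reading is not tied to 2,5-dimethoxyphenyl alone. With (4-chlorophenyl)amino in place of methyl on a carbonyl carbon, the series shows a number 42 percentage points lower from compound 1 to compound 3 (beyond the scatter), so a second aryl urea also stands well apart from compound 1. No measurement available here accounts for that gap.

From the compounds shown here alone, whether a methylamino group, an unsubstituted phenyl or a longer alkyl chain in this place reads nearer compound 1 or nearer compound 3 stays open.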